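From 2-fluorobenzyl to 1-phenylethenyl on the shared core

The source may hold more compounds than are shown below. What is called first, only, known or untested is meant among the compounds shown, and "the series" means these compounds.

In a functional assay on CHO-K1 cells for antagonist activity at adenosine receptor A1 (Homo sapiens), read by a beta-galactosidase reporter and cAMP accumulation, with stated times of 15 min and 6 h (a lower number here means a stronger inhibitor, a higher number a weaker inhibitor), compound 1 `COc1ccccc1Cc1cc2c(N)nc(-c3cccc(C#N)c3)nc2s1` gives 129 nM. For compound 2 `N#Cc1cccc(-c2nc(N)c3cc(Cc4ccccc4F)sc3n2)c1` the read-out is a limit, < 16 nM. The step is an at least 8.0-fold lower number from compound 1 to compound 2 (0.90 log units; beyond the scatter); the limit of < 16 nM in this assay, at which 1 of the 2 values shown sits, marks where compound 2 sits. Compound 3 `C=C(c1ccccc1)c1cc2c(N)nc(-c3cccc(C#N)c3)nc2s1` carries 1-phenylethenyl in place of 2-fluorobenzyl on an aromatic carbon. Among the compounds with values here, the one measured step altered only the substituent on the benzyl ring, not the link to the core, so it bears on this change only loosely. Since the fluorine that accompanied an at least 8.0-fold lower number from compound 1 to compound 2 (0.90 log units; beyond the scatter) is lost here, a somewhat weaker inhibitor than compound 2 is expected. Compound 3 is expected at 40 nM, between 10 nM and 160 nM. The estimated step is an at least 2.5-fold higher number from compound 2 to compound 3 (0.39 log units; beyond the scatter).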

Compound 3, inhibition constant: > 1000 nM
Compound 3: no number, only a limit; the forecaster's own chance of this, stated with the estimate: 25%; middle value at least 25-fold (1.39 log units) from the limit.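

The read-out for compound 3 is only a limit: the limit of > 1000 nM in this assay, at which 1 of the 3 values shown sits.

Placing 1-phenylethenyl on the aromatic carbon next to the ring sulfur gives an at least 62-fold higher number from compound 2 to compound 3 (1.79 log units; beyond the scatter), and replacing 2-methoxybenzyl gives an at least 7.7-fold higher number from compound 1 to compound 3 (0.88 log units; beyond the scatter). This position therefore responds to more than the substituent on the benzyl ring, as both substituted benzyl compounds read as stronger inhibitors than compound 3.

Still open, from the compounds shown here alone, is whether the loss follows the 1-phenylethenyl link or the missing ring substituent. A saturated 1-phenylethyl group or a benzoyl group, and a fluoro-substituted 1-phenylethenyl group, would separate these two readings.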